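Moving a fluorine on the phenyl ring and cytotoxicity

The compounds below may be only part of what the source reports. "The series", "measured", "known", "first", "only" and "open" are said of these compounds alone.

Three measured compounds share one core, in which a sulfonamide-bearing aromatic ring is joined to a five-membered aromatic ring that carries an aryl group on a ring nitrogen. Compound 1 `O=c1[nH]cc(S(=O)(=O)Nc2ccc(-c3cn(-c4ccccc4)nn3)cc2)c(=O)[nH]1` is recorded in an ADME assay on L02 cells (Homo sapiens) for cytotoxicity, read by MTT assay, with a stated time of 24 h (on this read-out lower numbers stand for higher toxicity in this test and higher numbers for lower toxicity in this test), as "not toxic" (no number reported), without a number. Compound 2 `Cc1cccc(-n2cc(-c3ccc(NS(=O)(=O)c4c[nH]c(=O)[nH]c4=O)cc3)nn2)c1` carries a 3-methylphenyl group and gives 39000 nM in this assay. Compound 3 `O=c1[nH]cc(S(=O)(=O)Nc2ccc(-c3cn(-c4ccccc4F)nn3)cc2)c(=O)[nH]1` carries a 2-fluorophenyl group instead. For compound 3 the result in this assay is only a limit of the test, > 100000 nM, so no single number is known. Among the compounds with values here, the one directly measured step, an at least 2.5-fold higher number from compound 2 to compound 3 (0.40 log units; beyond the scatter), runs toward lower toxicity. Its true size is open, since compound 3 sits at the limit of > 100000 nM in this assay, at which 1 of the 3 values shown sits.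

Compound 4 `O=c1[nH]cc(S(=O)(=O)Nc2ccc(-c3cn(-c4cccc(F)c4)nn3)cc2)c(=O)[nH]1` has not been measured. It differs from compound 3 by 3-fluorophenyl in place of 2-fluorophenyl on an aromatic nitrogen: the same fluorine, moved to another place on the ring. Within the data shown here, no measured step compares a 2-fluorophenyl with a 3-fluorophenyl group, so the expectation rests on compound 3 already standing at the limit. The change from compound 3 to compound 4 is therefore expected to be a number no higher from compound 3 to compound 4 (the limit leaves the size open), nothing beyond the scatter. Compound 4 is expected to give about 100000 nM in this assay, within a range from 40000 nM to 300000 nM, and most likely again only as a limit.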

Compound 4, half-maximal cytotoxic concentration: "not toxic" (no number reported)
Compound 4 has no reported number here, so the estimate cannot be set against anything.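

In this assay, within the data shown here, compound 4 is recorded as "not toxic" (no number reported), so no step between compound 3 and compound 4 can be read. The compounds shown leave open whether 3-fluorophenyl in place of 2-fluorophenyl changes the result at all, and where compound 1 and compound 4 would stand in numbers against compound 2.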